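Capping the hydroxy group of compound 2 with methyl

A few compounds are considered here, and "the series" means these few. Any claim that something is new, unique, unknown or untested is made for them only; others in the source may bear on it.

Measured so far in a functional assay on KB 3-1 cells (Homo sapiens), with a stated time of 1 h; a lower number here means that less compound is needed, a higher number that more compound is needed for the effect
- compound 1 `CC(=O)Oc1cc2oc(-c3ccccc3)cc(=O)c2c(OC(C)=O)c1OC(C)=O` gives 6800 nM
- compound 2 `CCCCCCOc1cc2oc(-c3ccccc3)cc(=O)c2c(O)c1OCCCCCC` gives 1000 nM

Compound 2 has the lower number of the two, and its gap to compound 1 lies beyond the usual scatter. Compound 3 `CCCCCCOc1cc2oc(-c3ccccc3)cc(=O)c2c(OC)c1OCCCCCC` carries the change methyl in place of hydrogen on an oxygen on an aromatic ring with methyl in place of hydrogen on an oxygen on an aromatic ring (hydroxy to methoxy). Among the compounds with values here, no measured pair shows this change, so the expectation is only loosely grounded. In this assay the expected change is a 1.5-fold higher number from compound 2 to compound 3 (0.18 log units; within the scatter) in size, a modest rise that may stay within the scatter. Compound 3 is estimated at 1500 nM with an expected range from 400 nM to 6000 nM as its ends.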

Compound 3, half-maximal effective concentration: 1300 nM
Estimate against measurement, compound 3: 1.2-fold (0.06 log units) above, within the range that was stated.
By their numbers in this assay, from the lowest: compounds 2 and 3 (each within the scatter of the next); then compound 1.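

In this assay, within the data shown here, hydroxy to methoxy on this oxygen on an aromatic ring gives a 1.3-fold higher number from compound 2 to compound 3 (0.11 log units; within the scatter), the first single-place step. Compound 2 and compound 3 thus stay within the scatter of each other, so in this pair the hydrogen on that oxygen can give way to methyl without a readable difference. No supporting data bear on why the two compounds read alike. On these data alone, whether a longer chain, an amine or a carboxylic acid on this oxygen would read the same remains open. Also open, as far as these compounds go, is whether hydroxy to methoxy reads alike with other groups on the remaining oxygens of the shared core.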